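The source may report more compounds than this note shows. Statements on the series, on what has been measured and on what is new or still open speak of the compounds shown alone.

Compound 1 `COc1cc(C)cc(-c2c(-c3ccnc(-c4ccc(C(C)=O)cc4)c3)cnn2CC#N)c1` — 80%
Compound 2 `COc1cc(C)cc(-c2nn(CC#N)cc2-c2ccnc(-c3ccc(N(C)C)cc3)c2)c1` — 61%

In a functional assay on K562 cells (Homo sapiens) for cytotoxicity, read by sulforhodamine B assay, with a stated time of 48 h, tested at 0.01 uM (a higher number here means a weaker effect of the compound at the concentration tested, a lower number a stronger effect), compound 1 gives 80%, the highest of the two numbers measured. Compound 2 gives 61%, a number that lies beyond the scatter below that of compound 1. Compound 3 `COc1cc(C)cc(-c2c(-c3ccnc(-c4ccc(N(C)C)cc4)c3)cnn2CC#N)c1` has not yet been measured; it differs from compound 1 in one place: dimethylamino in place of acetyl on an aromatic carbon. Going by the values given here, no measured pair shows this exact change, so the step is expected on the basis of compound 2, whose value 61% carries the same group. Compound 3 is expected to sit lower than compound 1, with an estimated step of a number 17 percentage points lower from compound 1 to compound 3 (beyond the scatter), and its estimated value is 63% (range 45% to 80%).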

Compound 3, a percentage reported as activity, at one concentration (the size of the read-out at that concentration, not a potency): 34%
For compound 3 the middle estimate is 29 percentage points above the measured one; measured number outside the range, below it.
By their numbers in this assay, from the lowest: compound 3; then compound 2; then compound 1.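

In this assay, going by these compounds alone, the exchange of acetyl for dimethylamino on the aromatic carbon, para to a large group, reads as a number 46 percentage points lower from compound 1 to compound 3 (beyond the scatter) and is the first step that isolates this position. It shows that the read-out responds strongly to the group held here, although both groups have the same count of heavy atoms. Nothing measured here accounts for the size of this step. The compounds shown leave open whether a smaller amine such as methylamino, a cyclic amine such as morpholine, or a carboxylic acid at this place would give a similar number.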